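Working notes: from compound 3 to compound 4

The compounds below may be only part of what the source reports. "The series", "measured", "known", "first", "only" and "open" are said of these compounds alone.

Values measured so far in a functional assay on A 172 cells (Homo sapiens) for cytotoxicity, read by colorimetric assay and MTT assay; a higher number here means a weaker inhibitor, a lower number a stronger inhibitor
- compound 1 `COc1cccc2cc(-c3ccccc3)c(O)nc12` at 10000 nM
- compound 2 `COc1cc(OC)c2cc(-c3ccc(OCc4ccccc4)cc3)c(O)nc2c1` at 10000 nM
- compound 3 `COc1ccc(-c2cc3c(OC)cc(OC)cc3n(CC#N)c2=O)cc1` at 10000 nM

Compound 3 at 10000 nM stands level with compound 1 and compound 2, so the three values do not separate. For the measured compounds named here, compound 4 `CCN(CC)C(=O)CCn1c(=O)c(-c2ccc(OC)cc2)cc2c(OC)cc(OC)cc21` carries (diethylcarbamoyl)methyl in place of cyano on a saturated chain carbon bound to an aromatic nitrogen as its only change. Going by the values given here, no measured pair isolates a single change, so this assay offers no direct precedent and no direction. No step beyond the scatter is expected. The expected change is no change at the digits printed from compound 3 to compound 4 (within the scatter) for now. Compound 4 is estimated at 10000 nM with an expected range from 4000 nM to 20000 nM as a working figure.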

Compound 4, half-maximal inhibitory concentration: 10000 nM
Estimate against measurement, compound 4: no gap at the digits printed; measured number inside the range.
By their numbers in this assay, from the lowest: compounds 1, 2, 3 and 4 (each within the scatter of the next).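

In this assay, (diethylcarbamoyl)methyl in place of cyano on a saturated chain carbon bound to an aromatic nitrogen gives no change at the digits printed from compound 3 to compound 4 (within the scatter). For the compounds shown here, this is the first comparison that isolates one change, and it shows that a group of 8 heavy atoms in place of one of 2 at this position leaves the read-out unmoved. Nothing measured on these compounds bears on this result.

As far as these compounds go, whether an amine or a carboxylic acid on this chain would separate from compound 4 stays open. So does the effect of any change on the shared core.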